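The compounds below may be only part of what the source reports. "The series", "measured", "known", "first", "only" and "open" are said of these compounds alone.

Compound 1 `CC1(C)O[C@H]2O[C@H](Cn3cc(CN4C(=O)/C(=N\Nc5ccccc5)c5ccccc54)nn3)[C@H](O)[C@H]2O1` is one of three closely related compounds for which a toxicity read-out is known. In an ADME assay on Vero cells (Chlorocebus sabaeus) for cytotoxicity, read by fluorescence and resazurin assay, with a stated time of 3 days (on this read-out higher numbers stand for lower toxicity in this test and lower numbers for higher toxicity in this test), compound 1 gives 82100 nM. Its two companions are compound 2 `COc1ccc(N/N=C2\C(=O)N(Cc3cn(C[C@H]4O[C@@H]5OC(C)(C)O[C@@H]5[C@H]4O)nn3)c3ccccc32)cc1`, which in this assay gives 74500 nM, and compound 3 `CC1(C)O[C@H]2O[C@H](Cn3cc(CN4C(=O)/C(=N\Nc5ccc(F)cc5)c5ccccc54)nn3)[C@H](O)[C@H]2O1`, which gives 83800 nM. Compound 1 stands second highest of the three numbers, but none of the three is separated from the others: a 1.1-fold lower number from compound 1 to compound 2 (0.04 log units; within the scatter), a 1.0-fold higher number from compound 1 to compound 3 (0.01 log units; within the scatter) and a 1.1-fold higher number from compound 2 to compound 3 (0.05 log units; within the scatter) all stay within the scatter of the measurement.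

Compound 4 `O=C1/C(=N\Nc2ccccc2)c2ccccc2N1Cc1cn(O[C@@H]2O[C@H](CO)[C@H](O)[C@H](O)[C@H]2O)nn1` takes a different route. It differs from compound 1 as follows: a group of 12 heavy atoms (6 carbon, 6 oxygen; one six-membered non-aromatic ring with 1 hetero atom) in place of a group of 12 heavy atoms (8 carbon, 4 oxygen; one five-membered non-aromatic ring with 1 hetero atom, one five-membered non-aromatic ring with 2 hetero atoms), on an aromatic nitrogen. Within the data shown here, all three measured steps concern a substituent on an aromatic carbon, not the aromatic nitrogen that is altered here, so no measured step bears directly on this change. What the measured set does show is that a substituent swap at the periphery of the shared core left the read-out unmoved, with every compound clustered near the same value. On that basis compound 4 is expected to remain in the same region, with a 1.0-fold lower number from compound 1 to compound 4 (0.01 log units; within the scatter) not exceeding the scatter. The estimate for compound 4 in this assay is 80000 nM, with a range from 40000 nM to 160000 nM.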

Compound 4, half-maximal cytotoxic concentration: 83400 nM
Compound 4: the middle estimate sits 1.0-fold (0.02 log units) below what was measured; the measured number falls inside the stated range.
By their numbers in this assay, from the lowest: compounds 2, 1, 4 and 3 (each within the scatter of the next).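

The earlier compounds shown here varied only a substituent on an aromatic carbon, whereas compound 4 carries its change on the aromatic nitrogen of the five-membered aromatic ring with 3 nitrogen, and in this assay the exchange of the group with two five-membered non-aromatic rings for (3,4,5-trihydroxy-6-(hydroxymethyl)oxan-2-yl)oxy gives a 1.0-fold higher number from compound 1 to compound 4 (0.01 log units; within the scatter), so this second place in the molecule also leaves the read-out undisturbed. The step holds even though the entering group has 4 hydrogen-bond donors, 6 hydrogen-bond acceptors and 5 defined stereocentres, against 1 hydrogen-bond donor, 4 hydrogen-bond acceptors and 4 defined stereocentres in the group that leaves. Nothing in the available data accounts for this outcome.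

Going by these compounds, whether the read-out would stay as steady with an amine or a carboxylic acid at this nitrogen, or with a plain alkyl chain in place of either ring-bearing group, remains open. Also open, on these data alone, is whether (3,4,5-trihydroxy-6-(hydroxymethyl)oxan-2-yl)oxy would leave the number in the same region when combined with the methoxy of compound 2 or the fluoro of compound 3.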